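Methyl for bromo on the aryl ring: an untested analog

The source may report more compounds than this note shows. Statements on the series, on what has been measured and on what is new or still open speak of the compounds shown alone.

Measured so far:
- compound 1, `Cc1ccc2c(c1)C(=O)/C(=C(\S)N(C)c1ccccc1)C(=O)N2C`: 20%
- compound 2, `CN1C(=O)/C(=C(/S)N(C)c2ccccc2)C(=O)c2cc(Br)ccc21`: 56%
- compound 3, `CN1C(=O)/C(=C(/S)N(C)c2ccc(Br)cc2)C(=O)c2cc(Cl)ccc21`: 50%

Of the compounds shown here, three have been tested in a functional assay on the whole organism for inhibition, with Mus musculus as the target, at a dose of 10 mg/kg by the oral route; a lower number here means less inhibition, a higher number more inhibition at the dose given (going by the name of the read-out). Compound 2 gives 56%, and compound 3 gives 50%; these two values lie within the usual scatter of each other. Compound 1 gives 20%. Compound 1 and compound 2 differ in one place, described as methyl in place of bromo on an aromatic carbon, and the step of a number 36 percentage points lower from compound 2 to compound 1 (beyond the scatter). How the core of compound 3 differs from the core of compound 2 is not broken down here.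

Compound 4, `Cc1ccc(N(C)/C(S)=C2/C(=O)c3cc(Cl)ccc3N(C)C2=O)cc1`, has not yet been measured in this assay. It differs from compound 3 by methyl in place of bromo on an aromatic carbon. This is the same kind of change as that from compound 2 to compound 1, but not the same: in compound 1 the methyl stands on a ring that is part of a fused system of two rings, meta and para to a fused ring, while in compound 4 it stands on a six-membered ring of carbon only, para to a large group.

Because the change from compound 2 to compound 1 gave a number 36 percentage points lower from compound 2 to compound 1 (beyond the scatter), a drop of a similar direction is expected for compound 4, though its size is uncertain since the place of the change differs. The expected step is a number 25 percentage points lower from compound 3 to compound 4 (beyond the scatter). For compound 4 the estimate in this assay is 25%, with a range from 8% to 45%.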

Compound 4, a percentage reported as inhibition, in the whole organism at one dose (the size of the read-out at that dose, not a potency): 23%
For compound 4 the middle estimate is 2 percentage points above the measured one; measured number inside the range.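

In this assay, methyl in place of bromo on the 4-bromophenyl group gives a number 27 percentage points lower from compound 3 to compound 4 (beyond the scatter), and this step can be set beside the earlier one, where the same swap was made at a different place on a different core: the same change on two cores in this assay, a number 36 percentage points lower (beyond the scatter) from compound 2 to compound 1 and a number 27 percentage points lower (beyond the scatter) from compound 3 to compound 4, 9 percentage points apart, within the scatter of two such steps. In both pairs, then, the change goes the same way, and the two steps cannot be told apart in size, so within this small series the loss seen on one core carries over to the other. Among the compounds shown here, this rests on only two pairs, however: it does not show that the change would behave alike on any further core, and it does not explain why the number falls, since a single-dose percentage in the whole organism says nothing about the cause.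

The swaps shown compare only bromo and methyl, so it remains open whether the drop belongs to methyl itself or whether bromo is the unusual partner. Going by these compounds, how a carboxylic acid, an amine or a longer chain such as propyl would fare at the same place on the shared core also remains open.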